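A few compounds are considered here, and "the series" means these few. Any claim that something is new, unique, unknown or untested is made for them only; others in the source may bear on it.

Measured so far, in an ADME assay on MT4 cells (Homo sapiens) for cytotoxicity; on this read-out higher numbers stand for lower toxicity in this test and lower numbers for higher toxicity in this test:
compound 1 `O=C(Nc1ccccn1)c1nc[nH]c1C(=O)O`: > 20000 nM, an assay limit rather than a number.
compound 2 `Nc1ccc(NC(=O)c2nc[nH]c2C(=O)O)cc1`: > 20000 nM, likewise an assay limit.

Compound 1 stands at the limit of this assay; its entry is a limit and not a measured number. Compound 2 sits at the same limit. Both entries rest at the limit of > 20000 nM in this assay, at which 2 of the 2 values shown sit, so no order between the two compounds can be read and no toxicity has appeared within the tested range.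

Compound 3 `O=C(Nc1ccccn1)c1nc[nH]c1C(=O)N1CCNCC1` remains to be measured. It differs from compound 1 by piperazin-1-yl in place of hydroxy on a carbonyl carbon. Going by the values given here, no step between measured compounds exists to indicate the size of such a change in this assay. Given compound 1 at the limit of > 20000 nM in this assay, at which 2 of the 2 values shown sit, the expected step is a number no higher from compound 1 to compound 3 (the limit leaves the size open), none beyond the scatter. Compound 3 is therefore estimated at 20000 nM, with a range from 8000 nM to 60000 nM, and is most likely to be reported again only as a limit.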

Compound 3, half-maximal cytotoxic concentration: > 20000 nM
Compound 3 ended at the assay's limit; the forecaster's own chance of this, stated with the estimate: 70%; the middle value sits exactly at the limit.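

Compound 1 and compound 3 both end at a limit, not a number, so piperazin-1-yl in place of hydroxy gives no readable step: the limit of > 20000 nM in this assay, at which 3 of the 3 values shown sit. The compounds shown leave open at what concentration, if any, cytotoxicity would appear for any of them.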